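The compounds below may be only part of what the source reports. "The series", "measured", "known", "first", "only" and "open" are said of these compounds alone.

Compound 1 `Cc1nc(S(C)(=O)=O)ccc1Oc1ncnc(OC2CCN(C(=O)OC(C)(C)CF)CC2)c1F`: 138 nM
Compound 2 `Cc1nc(S(C)(=O)=O)ccc1Oc1ncnc(OC2CCN(C(=O)C3(F)CCC3)CC2)c1F`: 123 nM

Among the compounds with values here, compound 2 holds the lowest of the two numbers in a functional assay on isolated protein for inhibition of Glucose-dependent insulinotropic receptor (Rattus norvegicus), read by HTRF and cAMP accumulation (a lower number here means that less compound is needed, a higher number that more compound is needed for the effect), though the only measured step, a 1.1-fold lower number from compound 1 to compound 2 (0.05 log units; within the scatter), lies within the scatter. Compound 3 `CCc1cnc(C(=O)N2CCC(Oc3ncnc(Oc4ccc(S(C)(=O)=O)nc4C)c3F)CC2)nc1` differs from compound 2 by a group of 8 heavy atoms (6 carbon, 2 nitrogen; one six-membered aromatic ring with 2 hetero atoms) in place of a group of 5 heavy atoms (4 carbon, 1 fluorine; one four-membered non-aromatic ring of carbon only), on a carbonyl carbon. Within the data shown here, that single step also changed the group on the carbonyl carbon, yet no measured step brings in an aromatic ring there, so the data bear on this change only loosely. Compound 3 is therefore expected to stay near compound 2, with a step of a 1.1-fold higher number from compound 2 to compound 3 (0.02 log units; within the scatter). The estimate for compound 3 in this assay is 130 nM, expected between 45 nM and 400 nM.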

Compound 3, half-maximal effective concentration: 40.8 nM
Estimate against measurement, compound 3: 3.2-fold (0.50 log units) above, outside the stated range (below it).
By their numbers in this assay, from the lowest: compound 3; then compounds 2 and 1 (each within the scatter of the next).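

In this assay, within the data shown here, the 5-ethylpyrimidin-2-yl group on the carbonyl carbon gives a 3.0-fold lower number from compound 2 to compound 3 (0.48 log units; beyond the scatter) and a 3.4-fold lower number from compound 1 to compound 3 (0.53 log units; beyond the scatter) and so provides the first steps at this position that lie beyond the scatter. The two earlier groups, neither with an aromatic ring, had stayed within the scatter of each other, so this position does respond to the group placed on it. Nothing measured here accounts for the size of these steps.

As far as these compounds go, whether a phenyl ring, a pyridin-2-yl group or the unsubstituted pyrimidin-2-yl would give similar steps remains open. So does how much of the change belongs to the ethyl group rather than to the ring.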